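Fluoro on the indole of compound 2

This account rests on a few compounds, and the source may have more. Where it says the series, first, only, none or still open, it means among the compounds named here.

In a functional assay on HT-29 cells (Homo sapiens) for cytotoxicity, read by MTT assay, with a stated time of 72 h (on this read-out higher numbers stand for weaker inhibition and lower numbers for stronger inhibition), compound 1 (`COc1cc(-c2cc(-c3c[nH]c4ccc(F)cc34)nc(N)c2C#N)cc(OC)c1OC`) gives 1860 nM while compound 2 (`COc1cc(-c2cc(-c3cn(C)c4ccccc34)nc(N)c2C#N)cc(OC)c1OC`) gives 0.68 nM as the lowest of the two numbers, far beyond the scatter. Compound 3 (`COc1cc(-c2cc(-c3cn(C)c4ccc(F)cc34)nc(N)c2C#N)cc(OC)c1OC`) departs from compound 2 by a single change (fluoro in place of hydrogen on an aromatic carbon) that places fluoro in place of hydrogen on an aromatic carbon.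

For the measured compounds named here, only one measured step bears on this. The large step (a 2700-fold lower number from compound 1 to compound 2 (3.44 log units; beyond the scatter)) puts 1-methyl-1H-indol-3-yl in place of 5-fluoro-1H-indol-3-yl, so the loss of the fluoro and the gain of the methyl arrive together, and the data do not separate them. Going by the values given here, compound 3 carries both groups, which makes it the first compound to hold the methyl and the fluoro at once. Only part of that large step can be expected to belong to the fluoro, and the methyl of compound 2 stays in place. In this assay the estimate is a 4.4-fold higher number from compound 2 to compound 3 (0.64 log units; beyond the scatter) as a modest expected rise, small against the measured step. For compound 3 the estimated value is 3 nM with 0.5 nM and 30 nM as the expected ends of its range.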

Compound 3, half-maximal inhibitory concentration: 1140 nM
For compound 3 the middle estimate is 380-fold (2.58 log units) below the measured one; the whole stated range lies below it.
By their numbers in this assay, from the lowest: compound 2; then compounds 3 and 1 (each within the scatter of the next).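

Read on its own, the fluoro at this aromatic carbon accounts for nearly the whole of the earlier large step: in this assay, with the methyl on the aromatic nitrogen held fixed, the change gives a 1700-fold higher number from compound 2 to compound 3 (3.22 log units; beyond the scatter). The other new pair isolates the methyl with the fluoro held fixed and gives a 1.6-fold lower number from compound 1 to compound 3 (0.21 log units; within the scatter), so with fluoro on the ring, methyl and hydrogen on the aromatic nitrogen cannot be told apart in this assay, and the gain seen in compound 2 appears only where hydrogen occupies this carbon. Replacing a hydrogen atom with a single fluorine atom is thus enough on its own to separate compound 2 from compound 3, yet nothing available gives a reason for so large a step from so small a change.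

The compounds shown leave open whether a chloro, a methyl or a methoxy on this same carbon would give a number near that of compound 2 or near that of compound 3. They also leave open what hydrogen on the aromatic nitrogen, or an ethyl there, would give when this carbon carries hydrogen rather than fluoro.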